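This account rests on a few compounds, and the source may have more. Where it says the series, first, only, none or still open, it means among the compounds named here.

In an ADME assay on microsomes from liver (Rattus norvegicus) for metabolic stability, using NADPH, with a stated time of 10 min (a lower number here means that less of the compound is left, a higher number that more of the compound is left), compound 1 `CCCCc1[nH]c(=O)c(S(=O)(=O)c2ccc(-c3ccncc3C)cc2)c(O)c1-c1c(OC)cccc1OC` gives 57%. Compound 2 `CCCCc1[nH]c(=O)c(S(=O)(=O)c2ccc(-c3cccnc3OC)cc2)c(O)c1-c1c(OC)cccc1OC` is reported as "not determined" (no result reported) in this assay, so no measured footing exists for it; the only measured point in the series is compound 1 with 57%. Compound 3 `CCCCc1[nH]c(=O)c(S(=O)(=O)c2ccc(-n3ccccc3=O)cc2)c(O)c1-c1c(OC)cccc1OC` differs from compound 2 by a group of 7 heavy atoms (5 carbon, 1 nitrogen, 1 oxygen; one six-membered aromatic ring with 1 hetero atom) in place of a group of 8 heavy atoms (6 carbon, 1 nitrogen, 1 oxygen; one six-membered aromatic ring with 1 hetero atom), on an aromatic carbon. Going by the values given here, with no measured step in this assay to lean on, no direction is expected beyond the scatter, and the middle of the expectation for compound 3 is anchored on compound 1 at 57%. For compound 3 the expected percent of compound remaining in this assay is 55%, with a range from 35% to 75%.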

Compound 3, percent of the compound remaining: 100%
Compound 3: middle estimate off by 45 percentage points, on the low side; measured number outside the range, above it.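

In this assay, changing only the ring group on this aromatic carbon, para to a large group, gives a number 43 percentage points higher from compound 1 to compound 3 (beyond the scatter), so the read-out responds strongly to what sits at this position. Going by these compounds alone, the entering ring, with its double bond outside aromatic rings, is the first group here with a large step attached to it. The step from compound 2 cannot be read, as compound 2 has no number, and nothing available explains the rise.

As far as these compounds go, whether the gain depends on a ring at all stays open. An amine or a carboxylic acid on this carbon could test that.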